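Furan carboxamides on a shared core: cytotoxicity notes

The source may report more compounds than this note shows. Statements on the series, on what has been measured and on what is new or still open speak of the compounds shown alone.

Measured compounds:
- compound 1 `O=C(Nc1ccccc1)c1cc2n(n1)CCCN(C(=O)c1ccco1)C2` — "not determined" (no result reported)
- compound 2 `CCc1ccoc1C(=O)N1CCCn2nc(C(=O)Nc3ccccc3)cc2C1` — 10000 nM

Compound 1 carries a plain furan-2-yl carbonyl on the ring amide nitrogen of the shared core. In an ADME assay on BEAS-2B cells (Homo sapiens) for cytotoxicity, read by fluorescence, with a stated time of 48 h (on this read-out lower numbers stand for higher toxicity in this test and higher numbers for lower toxicity in this test), compound 1 stands without a single number: the entry is "not determined" (no result reported), so there is no reference point for it. Among the compounds with values here, compound 2 is the one member with a reading; in this assay compound 2 gives 10000 nM, which is a weak effect on this read-out.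

Compound 3 `Cc1cc(C)c(C(=O)N2CCCn3nc(C(=O)Nc4ccccc4)cc3C2)o1` is the next member. Its change from compound 1 is 3,5-dimethylfuran-2-yl in place of furan-2-yl on a carbonyl carbon. Within the data shown here, no number exists for compound 1, so no step can be computed. Among the measured compounds shown here, the only anchor is compound 2, whose furan also carries an alkyl group. With that anchor, no shift beyond the scatter is expected in this assay for compound 3 relative to compound 2, in either direction.

Compound 3 is therefore expected to give about 10000 nM in this assay, with a range from 3000 nM to 30000 nM.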

Compound 3, half-maximal cytotoxic concentration: 2600 nM
Compound 3: the middle estimate sits 3.8-fold (0.59 log units) above what was measured, and the stated range ends above it.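

Working notes on the furan position: in this assay, 3,5-dimethylfuran-2-yl in place of 3-ethylfuran-2-yl on a carbonyl carbon gives a 3.8-fold lower number from compound 2 to compound 3 (0.59 log units; beyond the scatter), a modest move toward higher toxicity in this test. This position on the shared core therefore tells apart two alkylated furans, so the read-out depends on more than the mere presence of an alkyl group on the furan. The entry for compound 1 holds no single number, so its steps cannot be read and the effect of alkylating the plain furan stays unknown; nothing at hand accounts for the difference between the two alkylated furans.

Within the data shown here, with only one readable step, the separate contributions of the ethyl group, the two methyl groups and their placement on the furan remain unresolved. Also open, as far as these compounds go, is how this read-out would respond to a longer chain such as butyl on the furan, or to an amine or a carboxylic acid there, and whether any such group would move the value further from that of compound 3 in either direction.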